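Ring amine demethylation in a bridged nicotinic series

The source may report more compounds than this note shows. Statements on the series, on what has been measured and on what is new or still open speak of the compounds shown alone.

Measured so far:
compound 1 `CN1C[C@H]2C=C(c3cccnc3)C[C@H](C2)C1`: 31%
compound 2 `Clc1ccncc1C1=CC2CNCC(C1)C2`: 105%
compound 3 `COc1ccc(C2=CC3CC(C2)CN(C)C3)cn1`: 61%

In an in vitro functional assay on SH-SY5Y cells for agonist activity at Neuronal acetylcholine receptor; alpha3/beta4 (Homo sapiens), read by FLIPR and calcium flux (a higher number here means a larger maximal response, a lower number a smaller maximal response), compound 1 gives 31%, the lowest of the three numbers. The nearest is compound 3, which gives 61%, a gap beyond the scatter. The furthest is compound 2, which gives 105%, a wider gap, also beyond the scatter. Among the measured compounds shown here, the two compounds bearing methyl on the ring amine nitrogen, compound 1 and compound 3, both sit below compound 2, which carries hydrogen there; compound 2 differs elsewhere as well, so no single-change step between measured compounds is available.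

Compound 4 `C1=C(c2cccnc2)C[C@H]2CNC[C@@H]1C2` differs from compound 1 in one place: hydrogen in place of methyl on an amine nitrogen in a ring.

The expectation is a rise beyond the scatter, a number 44 percentage points higher from compound 1 to compound 4 (beyond the scatter), a direction suggested because compound 2 gives 105% with hydrogen on its ring amine nitrogen, although its further difference leaves the size of the step uncertain. Compound 4 is therefore expected to give about 75% in this assay, within a range of 45% to 105%.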

Compound 4, largest response reached (reported as percent of maximum), in percent of the reference or control that the assay uses: 142%
For compound 4 the middle estimate is 67 percentage points below the measured one; measured number outside the range, above it.
By their numbers in this assay, from the lowest: compound 1; then compound 3; then compound 2; then compound 4.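

In this assay, among the compounds shown here, hydrogen in place of methyl on an amine nitrogen in a ring gives a number 111 percentage points higher from compound 1 to compound 4 (beyond the scatter) and is the only single-change step so far, large and beyond the scatter. The earlier compounds shown here could link this position to the response only through compounds that also differed elsewhere, whereas here the rest of the core of compound 1 stays the same, so the full step belongs to this one change at this one position. Nothing at hand accounts for the size of this step.

Compound 2 and compound 3 have no partner among the compounds shown that differs only at the ring amine nitrogen, so it remains open whether a step of this size carries over to their other ring substituents. For the compounds shown here, also open is how the response in this assay changes with an ethyl group or a longer chain on that nitrogen, since methyl and hydrogen are the only two groups compared there on the core of compound 1.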